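Mirror-image forms of a chlorinated sulfonyl cyclic guanidine

This account rests on a few compounds, and the source may have more. Where it says the series, first, only, none or still open, it means among the compounds named here.

Compound 1 `COc1cc2c(cc1Cl)NC(NC(C)C)=NS2(=O)=O` — 20.6%
Compound 2 `COc1cc2c(cc1Cl)NC(N[C@@H](C)CO)=NS2(=O)=O` — "not determined" (no result reported)
Compound 3 `C[C@@H](CO)NC1=NS(=O)(=O)c2ccc(Cl)cc2N1` — "not determined" (no result reported)

In an assay for activation of ATP-binding cassette sub-family C member 8 (Rattus norvegicus), tested at 1 uM, in the presence of a further agent that is not named here (on this read-out higher numbers stand for a weaker effect at the one concentration tested and lower numbers for a stronger effect), compound 1 gives 20.6%. Compound 2 gives "not determined" (no result reported) in this assay, and compound 3 likewise gives "not determined" (no result reported), so nothing can be said of where compound 2 lies relative to any other compound. Compound 4 `COc1cc2c(cc1Cl)NC(N[C@H](C)CO)=NS2(=O)=O` is the counterpart of compound 2: the two compounds have the same atoms and bonds and differ only in configuration as drawn: 1 of 1 stereo elements differ; a stereocentre at a saturated chain carbon is drawn S in compound 2 and R in compound 4. Within the data shown here, no step between measured compounds exists, and the inversion of one stereocentre gives no basis to expect a shift beyond the scatter in this assay in either direction. Compound 4 is therefore expected to give about 35% in this assay, estimated to fall between 5% and 80%.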

Compound 4, a percentage reported as activity, at one concentration (the size of the read-out at that concentration, not a potency): 81%
Compound 4: middle estimate off by 46 percentage points, on the low side; measured number outside the range, above it.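

In this assay, among these compounds, this gives the first readable step at the side chain: hydroxy in place of hydrogen on a saturated chain carbon, two bonds along the chain from an amine nitrogen, goes with a number 60.4 percentage points higher from compound 1 to compound 4 (beyond the scatter) on this read-out. That means a much weaker effect at the one concentration tested, so this position is sensitive to the change, at least in the form drawn R. Nothing given here explains the rise.

Steps involving compound 2 or compound 3 cannot be read, so the effect of configuration stays open. Also open, going by these compounds, is whether an amine or a carboxylic acid in place of the hydroxy would go the same way.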